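Methoxy to hydroxy on the shared core

The source may report more compounds than this note shows. Statements on the series, on what has been measured and on what is new or still open speak of the compounds shown alone.

Three compounds share one core and differ in the groups at its two ends. Compound 1 `O=C(Nc1cccc(-n2cc(-c3ccncc3)c(-c3ccc(Cl)c(O)c3)n2)c1)Nc1cccc(C(F)(F)F)c1` gives 1820 nM in a functional assay on SR cells (Homo sapiens) for inhibition, read by sulforhodamine B assay, with a stated time of 48 h; on this read-out higher numbers stand for weaker inhibition of growth and lower numbers for stronger inhibition of growth. Compound 2 `O=C(Nc1cccc(-n2cc(-c3ccncc3)c(-c3ccc(Cl)c(O)c3)n2)c1)Nc1ccc(Cl)c(Cl)c1` gives 1140 nM in this assay; the step of a 1.6-fold lower number from compound 1 to compound 2 (0.20 log units; within the scatter) changes only the group on the amide-type nitrogen. Compound 3 `COc1cc(-c2nn(-c3cccc(NC(=O)Nc4ccc(Cl)c(C(F)(F)F)c4)c3)cc2-c2ccncc2)ccc1Cl` gives 884 nM in this assay, the lowest of the three numbers, within the scatter of compound 2 and beyond it only against compound 1.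

Compound 4 `O=C(Nc1cccc(-n2cc(-c3ccncc3)c(-c3ccc(Cl)c(O)c3)n2)c1)Nc1ccc(Cl)c(C(F)(F)F)c1` differs from compound 3 by hydrogen in place of methyl on an oxygen on an aromatic ring. Going by the values given here, no measured pair changes this same position, so the one step that exists, the change on the amide-type nitrogen, does not bear on it directly; it only shows that such a change moved the number within the scatter. Compounds 1 and 2, which carry the hydroxy group, sit near compound 3. Compound 4 is therefore expected to stay close to compound 3, a step of about a 1.1-fold higher number from compound 3 to compound 4 (0.05 log units; within the scatter) in this assay. The estimate for compound 4 is 1000 nM, with a range from 400 nM to 2500 nM.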

Compound 4, concentration for 50% growth inhibition: 715 nM
Beside the measured number, compound 4's estimate is 1.4-fold (0.15 log units) above it; measured number inside the range.
By their numbers in this assay, from the lowest: compounds 4, 3, 2 and 1 (each within the scatter of the next, the first and the last beyond it).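

Changing methoxy to hydroxy, the first direct test of this position, gives a 1.2-fold lower number from compound 3 to compound 4 (0.09 log units; within the scatter) in this assay, so for this pair the swap does not move the number outside the usual scatter. With the hydroxy group kept, the other end of the molecule gives two further readings: trifluoromethyl in place of chloro gives a 1.6-fold lower number from compound 2 to compound 4 (0.20 log units; within the scatter), whereas chloro in place of hydrogen gives a 2.5-fold lower number from compound 1 to compound 4 (0.41 log units; beyond the scatter), the only one of these three new steps to pass beyond the scatter. Nothing shown explains the size of any of these steps.

Going by these compounds alone, the methoxy and hydroxy groups are compared with only one group at the other end, so the same swap with the 3,4-dichlorophenyl or 3-(trifluoromethyl)phenyl end remains open. From the compounds shown here alone, it is also open how an amine, or an ethoxy group with its longer chain, would read at this position.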